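Phenyl to Pyridin-3-yl: Little Change Expected

The source may hold more compounds than are shown below. What is called first, only, known or untested is meant among the compounds shown, and "the series" means these compounds.

Compound 1 `O=C(O[C@H]1C[C@H](n2cc(F)c(=O)[nH]c2=O)O[C@@H]1COP(=O)(O)Oc1ccccc1)c1ccccc1` gives the lower of the two numbers in a functional assay on MRC5 cells (Homo sapiens) for cytotoxicity, read by MTT assay, with a stated time of 48 h (a higher number here means a weaker inhibitor, a lower number a stronger inhibitor), at 1270 nM. Among the compounds with values here, compound 2 `CCCCCCCCCc1ccc(OP(=O)(O)OC[C@H]2O[C@@H](n3cc(F)c(=O)[nH]c3=O)C[C@@H]2OC(=O)c2ccccc2)cc1` gives 39900 nM, and the single measured step is a 31-fold higher number from compound 1 to compound 2 (1.50 log units; beyond the scatter). Compound 3 `O=C(O[C@H]1C[C@H](n2cc(F)c(=O)[nH]c2=O)O[C@@H]1COP(=O)(O)Oc1cccnc1)c1ccccc1` differs from compound 1 by pyridin-3-yl in place of phenyl on an oxygen. Within the data shown here, no measured step bears directly on this change; the one known step concerns a nonyl chain and offers no guide here. Compound 3 is therefore expected to show a step of a 1.2-fold higher number from compound 1 to compound 3 (0.07 log units; within the scatter), not beyond the usual scatter. The estimate for compound 3 is 1500 nM, with a range from 500 nM to 5000 nM.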

Compound 3, half-maximal inhibitory concentration: 15600 nM
Beside the measured number, compound 3's estimate is 10-fold (1.02 log units) below it; measured number outside the range, above it.
By their numbers in this assay, from the lowest: compound 1; then compound 3; then compound 2.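

In this assay, the change from phenyl to pyridin-3-yl is not a silent swap: it gives a 12-fold higher number from compound 1 to compound 3 (1.09 log units; beyond the scatter). This position, on an oxygen whose other neighbours are phosphorus, therefore responds to exchanging a ring carbon for nitrogen, with the heavy-atom count unchanged, and not only to adding a nonyl chain. Nothing measured here explains the rise. Still open, on these data alone, is whether pyridin-4-yl or pyridin-2-yl would behave like pyridin-3-yl, and whether an amine or a carboxylic acid on the phenyl ring of compound 1 would also raise the number.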